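This account rests on a few compounds, and the source may have more. Where it says the series, first, only, none or still open, it means among the compounds named here.

Of the compounds shown here, three have so far been measured in a functional assay on the whole organism for antagonist activity, with Rattus norvegicus as the target; a higher number here means that more compound is needed for the effect, a lower number that less compound is needed. Compound 1 `c1ccc2c(c1)CCCCC2CCN1CCN(c2cccc3c2OCCO3)CC1` gives 5 mg/kg. Compound 2 `C1=C(CCN2CCN(c3cccc4c3OCCO4)CC2)c2ccccc2C1` gives 0.63 mg/kg in this assay, and compound 3 `c1ccc2c(c1)CC(CN1CCN(c3cccc4c3OCCO4)CC1)C2` gives 0.63 mg/kg. Compound 2 stands level with compound 3 at the digits shown, and these two share the lowest number of the three; compound 1 lies furthest from compound 2, with a higher number that is beyond the usual scatter.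

Compound 4 `c1ccc2c(c1)CCC2CCN1CCN(c2cccc3c2OCCO3)CC1` is not yet measured. It differs from compound 2 by a group of 9 heavy atoms (9 carbon; one five-membered non-aromatic ring of carbon only, one six-membered aromatic ring of carbon only) in place of a group of 9 heavy atoms (9 carbon; one five-membered non-aromatic ring of carbon only, one six-membered aromatic ring of carbon only), on a saturated chain carbon, two bonds along the chain from an amine nitrogen in a ring. The group that leaves carries one double bond outside aromatic rings; the group that enters, 2,3-dihydro-1H-inden-1-yl, does not.

Among the measured compounds shown here, no measured pair shows this change by itself. Compound 3 also carries a five-membered non-aromatic ring of carbon only without such a double bond and gives 0.63 mg/kg, so only a small step is expected, or none beyond the scatter. The step from compound 2 to compound 4 is expected to be a 1.6-fold higher number from compound 2 to compound 4 (0.20 log units; within the scatter). Compound 4 is estimated at 1 mg/kg in this assay, within a range of 0.3 mg/kg to 3 mg/kg.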

Compound 4, minimum effective dose: 0.63 mg/kg
The estimate for compound 4 lay 1.6-fold (0.20 log units) above the measured number; low and high end bracket the measured number.
By their numbers in this assay, from the lowest: compounds 2, 3 and 4 (each within the scatter of the next); then compound 1.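

Exchanging the group that carries the double bond for 2,3-dihydro-1H-inden-1-yl, with the same number of heavy atoms, in this assay produces no change at the digits printed from compound 2 to compound 4 (within the scatter). Among the compounds shown here, this is the first pair that differs in one place, and it shows that the double bond outside the aromatic ring is not needed to keep the dose in this range at this position, on a saturated chain carbon, two bonds along the chain from an amine nitrogen in a ring. Nothing available explains why the two groups give matching results.

From the compounds shown here alone, it remains open whether the result holds for other changes at this place, such as a hydroxyl group on the non-aromatic ring or a longer chain leading to the amine nitrogen. The pair also says nothing about how these compounds would behave in any other assay.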